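The source may report more compounds than this note shows. Statements on the series, on what has been measured and on what is new or still open speak of the compounds shown alone.

Measured compounds:
compound 1 `ClCc1ccc(Cn2cnc3c(Cl)ncnc32)cc1` — 2140 nM
compound 2 `ClCc1ccccc1Cn1cnc2c(Cl)nc(Cl)nc21` — 1470 nM
compound 3 `Nc1nc(Cl)c2ncn(Cc3ccc(CCl)cc3)c2n1` — 8130 nM

These three compounds were tested in a functional assay on KM12 cells (Homo sapiens) for cytotoxicity, read by sulforhodamine B assay, with a stated time of 48 h; a lower number here means a stronger inhibitor of growth, a higher number a weaker inhibitor of growth. Compound 2 has the lowest of the three numbers, but its gap to compound 1 lies within the scatter, so the two cannot be ranked; only compound 3 stands clearly apart, with a higher number than both.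

Compound 4 `Nc1nc(Cl)c2ncn(Cc3ccccc3CCl)c2n1` is derived from compound 2 by one change: amino in place of chloro on an aromatic carbon. Within the data shown here, no measured pair shows exactly this swap. The closest guide is the step of a 3.8-fold higher number from compound 1 to compound 3 (0.58 log units; beyond the scatter), where an amino group arrives at the same place of the shared core, there taking the spot of a hydrogen rather than a chloro. Compound 3 also carries the amino group and gives the highest number seen. On that basis the step from compound 2 to compound 4 is expected to run in the same direction, towards a weaker inhibitor, and to be of a modest size like a 3.7-fold higher number from compound 2 to compound 4 (0.57 log units; beyond the scatter).

Compound 4 is therefore estimated at 5500 nM, with a range from 2500 nM to 12000 nM.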

Compound 4, concentration for 50% growth inhibition: 15500 nM
For compound 4 the middle estimate is 2.8-fold (0.45 log units) below the measured one; the whole stated range lies below it.
By their numbers in this assay, from the lowest: compounds 2 and 1 (each within the scatter of the next); then compounds 3 and 4 (each within the scatter of the next).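

On the carbon between two ring nitrogen atoms, amino in place of chloro gives an 11-fold higher number from compound 2 to compound 4 (1.02 log units; beyond the scatter) in this assay, a large step towards a weaker inhibitor of growth. Together with a 3.8-fold higher number from compound 1 to compound 3 (0.58 log units; beyond the scatter), where amino takes the place of hydrogen at the same position, this shows the same direction from two different starting groups, with the change from chloro printed as large and the change from hydrogen as modest. Nothing measured here accounts for the size of either step.

Only hydrogen, chloro and amino have been seen at this position. As far as these compounds go, how a methylamino, a methoxy or a methyl group there would compare with the chloro of compound 2 remains open.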